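The source may report more compounds than this note shows. Statements on the series, on what has been measured and on what is new or still open speak of the compounds shown alone.

Values in a physicochemical assay for lipophilicity; on this read-out higher numbers stand for higher lipophilicity and lower numbers for lower lipophilicity:

- Compound 1 `C[C@H]1CC[C@@H]2[C@@H](OC(=O)[C@]23CC(c2c(Cl)cccc2Cl)=NO3)[C@]2(C)C(=O)C=C[C@@]12O`: 2.67
- Compound 2 `COc1ccc(C2=NO[C@]3(C2)C(=O)O[C@@H]2[C@H]3CC[C@H](C)[C@]3(O)C=CC(=O)[C@@]23C)cc1`: 1.47
- Compound 3 `C[C@H]1CC[C@@H]2[C@@H](OC(=O)[C@]23CC(c2ccccc2[N+](=O)[O-])=NO3)[C@]2(C)C(=O)C=C[C@@]12O`: 1.37

Compound 3 sits at the low end of these numbers. The step that links it to its nearest neighbour is a number 0.10 log units lower from compound 2 to compound 3 (within the scatter), while the step from the top of the set is a number 1.30 log units lower from compound 1 to compound 3 (beyond the scatter).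

Compound 4 `COc1ccc(C2=NO[C@]3(C2)C(=O)O[C@@H]2[C@H]3CC[C@H](C)[C@]3(O)C=CC(=O)[C@@]23C)cc1OC` carries 3,4-dimethoxyphenyl in place of 2-nitrophenyl on a carbon with a double bond to nitrogen.

The large steps, a number 1.20 log units lower from compound 1 to compound 2 (beyond the scatter) and a number 1.30 log units lower from compound 1 to compound 3 (beyond the scatter), both remove 2,6-dichlorophenyl, a group that neither compound 3 nor compound 4 carries, so they bear on this change only weakly. The closest guide is compound 2 at 1.47, whose 4-methoxyphenyl group is the nearest measured match to 3,4-dimethoxyphenyl. For the measured compounds named here, no measured step tests 3,4-dimethoxyphenyl itself. In this assay, no step beyond the scatter is therefore expected, and the estimated step is a number 0.13 log units higher from compound 3 to compound 4 (within the scatter). For compound 4 the estimated value is 1.5, with an expected range from 1.1 to 1.9.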

Compound 4, partition coefficient: 1.06
Beside the measured number, compound 4's estimate is 0.44 log units above it; measured number outside the range, below it.
By their numbers in this assay, from the lowest: compound 4; then compounds 3 and 2 (each within the scatter of the next); then compound 1.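

In this assay, methoxy in place of hydrogen on an aromatic carbon gives a number 0.41 log units lower from compound 2 to compound 4 (beyond the scatter) and shows that a change within one phenyl group at this position can move the read-out beyond the scatter. 3,4-dimethoxyphenyl in place of 2-nitrophenyl gives a number 0.31 log units lower from compound 3 to compound 4 (beyond the scatter) and so separates two groups at this position, whereas 4-methoxyphenyl and 2-nitrophenyl stayed within the scatter of each other. 3,4-dimethoxyphenyl in place of 2,6-dichlorophenyl gives a number 1.61 log units lower from compound 1 to compound 4 (beyond the scatter) and widens the span at this position, but no measured evidence accounts for these steps.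

The compounds shown leave open how an amine or a carboxylic acid on the phenyl group would read in this assay at this position. They also leave open whether a third methoxy would continue the downward step seen with the second.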